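Fluoro for Chloro on a Pyridinylmethyl Urea Tail

The source may report more compounds than this note shows. Statements on the series, on what has been measured and on what is new or still open speak of the compounds shown alone.

Compound 1 `Nc1ccccc1NC(=O)c1ccc(NC(=S)NCc2cncc(Br)c2)cc1`: > 2000 nM
Compound 2 `Nc1ccccc1NC(=O)c1ccc(NC(=O)NCc2ccc(Cl)nc2)cc1`: > 2000 nM
Compound 3 `Nc1ccccc1NC(=O)c1ccc(NC(=S)NCc2cncc(F)c2)cc1`: > 2000 nM

In an assay on isolated protein for inhibition of Nicotinamide phosphoribosyltransferase (Homo sapiens), read by fluorescence, with stated times of 5 min and 15 min (on this read-out higher numbers stand for weaker inhibition and lower numbers for stronger inhibition), compound 1 gives only a limit, > 2000 nM. Compound 3 likewise gives only a limit, > 2000 nM. Compound 2 also reaches only a limit, > 2000 nM, so it stands with the others at the limit of > 2000 nM in this assay, at which 3 of the 3 values shown sit. Among the measured compounds shown here, the one measured step, a step that the two limits leave unreadable from compound 1 to compound 3, is therefore unreadable in size. Compound 4 `Nc1ccccc1NC(=O)c1ccc(NC(=O)NCc2ccc(F)nc2)cc1` differs from compound 2 by fluoro in place of chloro on an aromatic carbon. For the measured compounds named here, no measured step bears on this change beyond the unreadable one, so no shift beyond the scatter is expected in this assay, and compound 4 is expected most likely to return a limit again. The expected step is a step that the limit leaves unreadable from compound 2 to compound 4, and compound 4 is estimated at 4000 nM, within 1500 nM to 20000 nM.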

Compound 4, half-maximal inhibitory concentration: > 2000 nM
Compound 4 gave a limit, no number (the forecaster's own chance of this, stated with the estimate: 85%); the middle value lies beyond the limit too.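

Compound 2 and compound 4 both return only a limit, so no step between them can be read in this assay: the limit of > 2000 nM in this assay, at which 4 of the 4 values shown sit.

The compounds shown leave open how strongly any of them inhibits, and whether fluoro in place of chloro changes inhibition at all.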